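Swapping trifluoromethoxy for hydroxy in a growth inhibitor

The compounds below may be only part of what the source reports. "The series", "measured", "known", "first", "only" and "open" are said of these compounds alone.

Compound 1 (`Oc1cccc2[nH]c(-c3ccc(-c4ccc(-c5ccc(C(F)(F)F)cc5)cc4)cc3)nc12`): 6100 nM
Compound 2 (`Oc1cccc2[nH]c(-c3ccc(-c4ccc(-c5ccc(OC(F)(F)F)cc5)cc4)cc3)nc12`): 2900 nM

In a functional assay on A2780 cells (Homo sapiens) for inhibition, read by sulforhodamine B assay (a higher number here means a weaker inhibitor of growth, a lower number a stronger inhibitor of growth), compound 2 stands lowest of the two at 2900 nM and so is the stronger growth inhibitor of the pair. Compound 3 (`Oc1ccc(-c2ccc(-c3ccc(-c4nc5c(O)cccc5[nH]4)cc3)cc2)cc1`) has not been measured yet. It has hydrogen in place of trifluoromethyl on an oxygen on an aromatic ring, so trifluoromethoxy becomes hydroxy (hydrogen in place of trifluoromethyl on an oxygen on an aromatic ring). Going by the values given here, one measured step bears on this, and only loosely: a 2.1-fold lower number from compound 1 to compound 2 (0.32 log units; beyond the scatter) in a swap of trifluoromethyl for trifluoromethoxy. Among the compounds with values here, that step is modest, yet neither of its groups is a hydroxy, and no measured compound shows what a hydroxy does here. Going by these compounds, the direction therefore stays open, and the best single guess is that no shift beyond the scatter will appear in this assay for this change. The expected change is a 1.2-fold lower number from compound 2 to compound 3 (0.06 log units; within the scatter) on this estimate. Within the data shown here, for compound 3 the estimated value is 2500 nM with an expected range from 600 nM to 10000 nM as a wide band, since only one step is available to guide it.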

Compound 3, concentration for 50% growth inhibition: 2920 nM
Compound 3: middle estimate off by 1.2-fold (0.07 log units), on the low side; low and high end bracket the measured number.
By their numbers in this assay, from the lowest: compounds 2 and 3 (each within the scatter of the next); then compound 1.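

In this assay, replacing trifluoromethoxy with hydroxy gives a 1.0-fold higher number from compound 2 to compound 3 (0.00 log units; within the scatter) and so leaves no difference that can be told from the scatter: this position accepts either group with the same reading. Hydroxy can also now be compared directly with trifluoromethyl, and the change gives a 2.1-fold lower number from compound 1 to compound 3 (0.32 log units; beyond the scatter) as a modest step, much like a 2.1-fold lower number from compound 1 to compound 2 (0.32 log units; beyond the scatter) seen for trifluoromethoxy. The trifluoromethyl group of compound 1 is thus the only one of the three whose number stands apart, and the three fluorine atoms on the oxygen of compound 2 are not needed to reach the level of growth inhibition that it shows. Nothing in the data explains why the hydroxy and trifluoromethoxy compounds read alike.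

Going by these compounds, it remains open how a methoxy, an amine or a carboxylic acid in this place on the aromatic ring would compare with hydroxy and trifluoromethoxy. On these data alone, it also remains open whether the oxygen itself matters, a question that a plain hydrogen or a methyl group on that aromatic carbon could help to answer.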